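This account rests on a few compounds, and the source may have more. Where it says the series, first, only, none or still open, it means among the compounds named here.

Compound 2, whose structure is `CCCCC/C(CC)=N\Nc1nc(-c2cccc([N+](=O)[O-])c2)cs1`, was tested in an assay on isolated protein for inhibition of Amine oxidase [flavin-containing] B (Homo sapiens), read by fluorescence, with a stated time of 20 min (a lower number here means a stronger inhibitor, a higher number a weaker inhibitor), and gave 355 nM. It sits alongside a single companion, compound 1, with the structure `CCC/C(CC)=N\Nc1nc(-c2cccc([N+](=O)[O-])c2)cs1`, which in this assay gave 189 nM; the step of a 1.9-fold higher number from compound 1 to compound 2 (0.27 log units; within the scatter) places the two within the scatter of each other, so neither can be called the stronger inhibitor on these numbers.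

The next compound, compound 3, has the structure `CCCC/C(CC)=N\Nc1nc(-c2cccc([N+](=O)[O-])c2)cs1`. Its difference from compound 2 is hydrogen in place of methyl on a saturated chain carbon, four bonds along the chain from a carbon with a double bond to nitrogen, so the chain is trimmed back by one carbon, leaving compound 3 intermediate in chain length between compound 1 and compound 2. Going by the values given here, the only measured step that bears on it is the chain extension from compound 1 to compound 2, which changed the number by a 1.9-fold higher number from compound 1 to compound 2 (0.27 log units; within the scatter), a shift too small to read as a real effect. A one-carbon trimming at the chain end is therefore expected to move the number little, if at all, beyond the scatter, with the value for compound 3 expected to land between its two neighbours.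

Compound 3 is estimated at 270 nM, with a range from 130 nM to 560 nM, an expected step of a 1.3-fold lower number from compound 2 to compound 3 (0.12 log units; within the scatter).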

Compound 3, half-maximal inhibitory concentration: 182 nM
Compound 3: the middle estimate sits 1.5-fold (0.17 log units) above what was measured; measured number inside the range.
By their numbers in this assay, from the lowest: compounds 3, 1 and 2 (each within the scatter of the next).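

Compound 3 fills the one-carbon gap in this chain series, and in this assay neither of its new steps leaves the scatter (a 2.0-fold lower number from compound 2 to compound 3 (0.29 log units; within the scatter); a 1.0-fold lower number from compound 1 to compound 3 (0.02 log units; within the scatter)). Hydrogen in place of methyl at this place, four bonds along the chain from a carbon with a double bond to nitrogen, therefore gives no readable difference, and methyl in place of hydrogen three bonds along gives none either, so the earlier lone step is now joined by two more that point the same way and all three chain lengths read as one level. No measured evidence is available that could explain why the number holds across this stretch of chain.

Only a short run of saturated chains on the shared core is shown, so the compounds leave open whether a much longer chain, or a chain ending in an amine or a carboxylic acid, would move the number beyond the scatter. As far as these compounds go, the ethyl group on the carbon with a double bond to nitrogen stays the same in all three compounds, so what a methyl group or a cyclohexyl ring in its place would do also remains open.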